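This account rests on a few compounds, and the source may have more. Where it says the series, first, only, none or still open, it means among the compounds named here.

Measured in an in vitro assay on UC11MG cells for binding affinity to Substance-P receptor (Homo sapiens), read by radioligand binding; on this read-out higher numbers stand for weaker inhibition and lower numbers for stronger inhibition:

Compound 1 `CN(Cc1cc(C(F)(F)F)cc(C(F)(F)F)c1)C(=O)c1cnc2ccccc2c1-c1ccccc1`: 0.03 nM
Compound 2 `Cc1nc2ccccc2c(-c2ccccc2)c1C(=O)N(C)Cc1cc(C(F)(F)F)cc(C(F)(F)F)c1`: 3.1 nM
Compound 3 `CN(Cc1cc(C(F)(F)F)cc(C(F)(F)F)c1)C(=O)c1c(CBr)nc2ccccc2c1-c1ccccc1`: 52 nM

Compound 3 gives the highest number of the three, set apart from compound 2 by a 17-fold higher number from compound 2 to compound 3 (1.22 log units; beyond the scatter) and from compound 1 by a 1700-fold higher number from compound 1 to compound 3 (3.24 log units; beyond the scatter). Compound 4 `CN(Cc1cc(C(F)(F)F)cc(C(F)(F)F)c1)C(=O)c1c(CO)nc2ccccc2c1-c1ccccc1` differs from compound 3 by hydroxy in place of bromo on a saturated chain carbon bound to an aromatic carbon. Among the measured compounds shown here, no measured step exchanges bromo for hydroxy. The steps that touch the same carbon are a 100-fold higher number from compound 1 to compound 2 (2.01 log units; beyond the scatter) and a 17-fold higher number from compound 2 to compound 3 (1.22 log units; beyond the scatter), both large and both toward weaker binding, so substitution at this place is poorly tolerated. Because of a 17-fold higher number from compound 2 to compound 3 (1.22 log units; beyond the scatter), the hydroxy group is expected to recover part of that loss, a step of a 3.5-fold lower number from compound 3 to compound 4 (0.54 log units; beyond the scatter). Compound 4 is therefore estimated in this assay at 15 nM, between 3 nM and 80 nM.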

Compound 4, half-maximal inhibitory concentration: 16 nM
The estimate for compound 4 lay 1.1-fold (0.03 log units) below the measured number, within the range that was stated.
By their numbers in this assay, from the lowest: compound 1; then compound 2; then compound 4; then compound 3.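

In this assay, bromomethyl to hydroxymethyl on this carbon gives (a 3.3-fold lower number from compound 3 to compound 4 (0.51 log units; beyond the scatter)), so the identity of the group matters here, not only its presence. Hydroxy in place of hydrogen on the saturated chain carbon still weakens binding (a 5.2-fold higher number from compound 2 to compound 4 (0.71 log units; beyond the scatter)), and hydroxymethyl remains far from the hydrogen of compound 1 (a 530-fold higher number from compound 1 to compound 4 (2.73 log units; beyond the scatter)), so neither group tested on this carbon matches hydrogen. Nothing available explains these differences. As far as these compounds go, whether an amine, a carboxylic acid or a longer chain on this carbon would bind more or less strongly than hydroxymethyl remains open.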